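Swapping a triazole for a methylpyrazole on the shared core

The source may hold more compounds than are shown below. What is called first, only, known or untested is meant among the compounds shown, and "the series" means these compounds.

Compound 1, `c1ccc(-c2nc[nH]n2)c(NCC2=NCCN2)c1`: 5.01 nM
Compound 2, `Cc1nc(-c2ccccc2NCC2=NCCN2)n(C)n1`: < 5020 nM

Of the compounds shown here, two have been tested in an in vitro functional assay on cells (Fibroblast) for agonist activity at Alpha-1B adrenergic receptor (Homo sapiens); on this read-out lower numbers stand for an effect already at smaller amounts and higher numbers for an effect only at larger amounts of compound. Compound 1 gives 5.01 nM, the only plain number among the results shown. For compound 2 the result in this assay is only a limit, < 5020 nM, and the limit of < 5020 nM in this assay, at which 1 of the 2 values shown sits, describes its position. Within the data shown here, compound 1 therefore stands alone as the single measured value.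

Compound 3, `Cn1nccc1-c1ccccc1NCC1=NCCN1`, has not yet been tested. It differs from compound 1 in one place: 1-methyl-1H-pyrazol-5-yl in place of 1H-1,2,4-triazol-3-yl on an aromatic carbon. Among the measured compounds shown here, with no measured pair of this kind to lean on, the size of the step in this assay cannot be read from the data; the expectation is a loss of activity beyond the usual scatter, but a modest one. The step expected from compound 1 to compound 3 is a 10-fold higher number from compound 1 to compound 3 (1.00 log units; beyond the scatter). Compound 3 is thus estimated at 50 nM, within a range from 5 nM to 500 nM.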

Compound 3, half-maximal effective concentration: < 100000 nM
Compound 3: only a limit was reported; the forecaster's own chance of this, stated with the estimate: 20%; the middle value does not contradict the limit.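

Among these compounds, the result for compound 3 is only a limit, so no step from compound 1 to compound 3 can be read from it: the limit of < 100000 nM in this assay, at which 1 of the 3 values shown sits.

The compounds shown leave open how much the activity of the shared core changes when 1-methyl-1H-pyrazol-5-yl stands in place of 1H-1,2,4-triazol-3-yl.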